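The compounds below may be only part of what the source reports. "The series", "measured", "known", "first", "only" and "open" are said of these compounds alone.

Measured compounds:
compound 1, `COc1cc(OC)c2c(=O)cc(-c3ccc(OCCCN(C)C)cc3)oc2c1`: 86%
compound 2, `COc1cc(OC)c2c(=O)cc(-c3ccc(OC4CCNCC4)cc3)oc2c1`: "not determined" (no result reported)
compound 3, `COc1cc(OC)c2c(=O)cc(-c3ccc(OCCCN)cc3)oc2c1`: "not determined" (no result reported)

In a functional assay (Homo sapiens) for antiproliferative activity, read by resazurin assay, with a stated time of 48 h, tested at 20 uM (a higher number here means a stronger effect of the compound at the concentration tested, a lower number a weaker effect), compound 1 gives 86%. Within the data shown here, compound 3 stands without a number in this assay, and compound 2 likewise carries no number, so no step between measured compounds can be taken from the series. Compound 4, `COc1cc(OC)c2c(=O)cc(-c3ccc(Br)cc3)oc2c1`, differs from compound 3 in one place: bromo in place of 3-aminopropoxy on an aromatic carbon. Among the measured compounds shown here, with no measured step at hand, the size and direction of this change in this assay remain open; the only anchor is compound 1 with 86%. A sizeable effect at the tested concentration is still expected for compound 4, though with wide uncertainty. Compound 4 is expected to give about 55%, between 20% and 90%.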

Compound 4, a percentage reported as inhibition, at one concentration (the size of the read-out at that concentration, not a potency): 22%
The estimate for compound 4 lay 33 percentage points above the measured number, and the stated range covers the measured number.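

In this assay, among these compounds, the step of a number 64 percentage points lower from compound 1 to compound 4 (beyond the scatter) is the first measured change at this position, and it is large: bromo in place of 3-(dimethylamino)propoxy leaves much less of the effect, so the read-out depends on what this aromatic carbon carries. Steps involving compound 2 or compound 3 cannot be read. Nothing at hand explains the size of this drop. Still open, from the compounds shown here alone, is whether the terminal amine or the ether chain carries the step: a plain methoxy, or a propoxy chain ending in a hydroxyl or carboxylic acid, would separate the two. Going by these compounds, whether a longer chain would hold the effect also remains untested here.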